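Removing a Chain Methyl from a Tetrazole Leukotriene Ligand

The source may hold more compounds than are shown below. What is called first, only, known or untested is meant among the compounds shown, and "the series" means these compounds.

Two compounds share a core in which a quinoline-bearing ether is joined to a four-carbon chain. Compound 1 `CC(CCCC(=O)O)c1cccc(OCc2ccc3ccccc3n2)c1` carries a carboxy group at the end of that chain; in an assay on membranes from lung (Cavia porcellus) for binding affinity to cysteinyl leukotriene receptor (Homo sapiens) (a lower number here means a stronger inhibitor, a higher number a weaker inhibitor), compound 1 gives 90 nM. Compound 2 `CC(CCCc1nnn[nH]1)c1cccc(OCc2ccc3ccccc3n2)c1` replaces the carboxy with a 1H-tetrazol-5-yl group, and in this assay compound 2 gives 31 nM. Among the measured compounds shown here, that exchange gave a 2.9-fold lower number from compound 1 to compound 2 (0.46 log units; beyond the scatter), so compound 2 stands as the lower of the two numbers measured so far.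

Compound 3 `c1cc(CCCCc2nnn[nH]2)cc(OCc2ccc3ccccc3n2)c1` differs from compound 2 at a different spot: hydrogen in place of methyl on a saturated chain carbon bound to an aromatic carbon and a saturated chain carbon. For the measured compounds named here, no measured step touches this position; the one step in hand concerns only the chain end, so it offers no direct guide here. With nothing to point either way, the expectation for compound 3 is a number close to that of compound 2, allowing a wider range than usual for the uncertainty, which amounts to a 1.5-fold higher number from compound 2 to compound 3 (0.16 log units; within the scatter). The estimate for compound 3 in this assay is therefore 45 nM, with a range from 15 nM to 150 nM.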

Compound 3, inhibition constant: 20 nM
Compound 3: middle estimate off by 2.3-fold (0.35 log units), on the high side; the measured number falls inside the stated range.
By their numbers in this assay, from the lowest: compounds 3 and 2 (each within the scatter of the next); then compound 1.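

Removing the methyl from the saturated chain carbon bound to an aromatic carbon and a saturated chain carbon gives, in this assay, a 1.6-fold lower number from compound 2 to compound 3 (0.19 log units; within the scatter), so this methyl can be lost without a change that rises above the scatter of the measurement. Among the compounds shown here, the larger replacement of 4-carboxy-1-methylbutyl by 4-(1H-tetrazol-5-yl)butyl gives a 4.5-fold lower number from compound 1 to compound 3 (0.65 log units; beyond the scatter); it combines the exchange at the chain end with the loss of the methyl, and only this combined step and the exchange at the chain end alone lie beyond the scatter. Nothing available here explains why the methyl makes so little measurable difference.

The compounds shown place only methyl and hydrogen on this chain carbon, so the outcome with an ethyl group, a hydroxyl group or a fluorine atom there remains open. Also open, on these data alone, is whether a shorter or longer chain carrying the tetrazole would keep numbers like these, and whether compound 1, with its carboxylic acid, would respond in the same way to losing its methyl.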